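The source may report more compounds than this note shows. Statements on the series, on what has been measured and on what is new or still open speak of the compounds shown alone.

Three compounds that share one core and differ only in the ring attached to the carbonyl carbon of the amide have been measured in a functional assay on HCC1937 cells (Homo sapiens) for antiproliferative activity, read by CCK-8 assay, with a stated time of 72 h; a lower number here means a stronger inhibitor, a higher number a weaker inhibitor. Compound 1 `COc1ccc(C(=O)Nc2cccc(-c3oc4cc(-c5ccc(F)cc5)ccc4c(=O)c3O)c2)cc1` gives 5490 nM, compound 2 `O=C(Nc1cccc(-c2oc3cc(-c4ccc(F)cc4)ccc3c(=O)c2O)c1)c1ccc(Br)cc1` gives 8630 nM, and compound 3 `O=C(Nc1cccc(-c2oc3cc(-c4ccc(F)cc4)ccc3c(=O)c2O)c1)c1cccc(F)c1` gives 6590 nM. Compound 3 holds the second highest of the three numbers, but its neighbours lie close on either side: the step of a 1.2-fold higher number from compound 1 to compound 3 (0.08 log units; within the scatter) and the step of a 1.3-fold lower number from compound 2 to compound 3 (0.12 log units; within the scatter) are both within the scatter, so no order among the three can be claimed.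

Compound 4 `Cc1cc(C)cc(C(=O)Nc2cccc(-c3oc4cc(-c5ccc(F)cc5)ccc4c(=O)c3O)c2)c1` differs from compound 3 in one place: 3,5-dimethylphenyl in place of 3-fluorophenyl on a carbonyl carbon. Every measured step bears on this change, since each one also swaps the ring on the carbonyl carbon: a 1.6-fold higher number from compound 1 to compound 2 (0.20 log units; within the scatter), a 1.2-fold higher number from compound 1 to compound 3 (0.08 log units; within the scatter) and a 1.3-fold lower number from compound 2 to compound 3 (0.12 log units; within the scatter). None of these moved the number beyond the scatter. Because a 1.2-fold higher number from compound 1 to compound 3 (0.08 log units; within the scatter) and a 1.3-fold lower number from compound 2 to compound 3 (0.12 log units; within the scatter) are small, the expected step for compound 4 in this assay is a 1.0-fold lower number from compound 3 to compound 4 (0.01 log units; within the scatter), that is, none beyond the scatter. Compound 4 is therefore estimated at 6500 nM, with a range from 3000 nM to 14000 nM.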

Compound 4, half-maximal inhibitory concentration: 4860 nM
Beside the measured number, compound 4's estimate is 1.3-fold (0.13 log units) above it; measured number inside the range.
By their numbers in this assay, from the lowest: compounds 4, 1, 3 and 2 (each within the scatter of the next).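

In this assay the change to 3,5-dimethylphenyl on the carbonyl carbon gives a 1.4-fold lower number from compound 3 to compound 4 (0.13 log units; within the scatter). The other two new steps, a 1.8-fold lower number from compound 2 to compound 4 (0.25 log units; within the scatter) and a 1.1-fold lower number from compound 1 to compound 4 (0.05 log units; within the scatter), are also within the scatter, so a ring whose added groups are carbon only fits the same narrow band as the rings carrying methoxy, bromo or fluoro, and the four compounds can be put in no firm order. Even with a ring carrying two methyl groups instead of a single group, no step at this position has yet moved the number beyond the scatter, and no measurement at hand explains any of these steps.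

On these data alone, all four compounds carry a substituted phenyl ring on the carbonyl carbon, so it remains open whether a ring bearing an amine or a carboxylic acid, a saturated ring, or a longer carbon chain in that place would shift the number beyond the scatter. As far as these compounds go, the amide link and the 4-fluorophenyl group on the shared core are the same throughout, so what a change at either would do also remains open.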